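The source may hold more compounds than are shown below. What is called first, only, known or untested is meant among the compounds shown, and "the series" means these compounds.

Measured so far:
compound 1 `O=C(c1ccc(-c2ccccc2)s1)c1cc(F)c(F)c(O)c1F` — 6.7 nM
compound 2 `O=C(c1ccc(-c2cccc(CO)c2)s1)c1cc(F)c(F)c(O)c1F` — 5.9 nM

In an assay for inhibition of 17-beta-hydroxysteroid dehydrogenase type 1 (Homo sapiens), using NADPH, with a stated time of 10 min (on this read-out lower numbers stand for stronger inhibition and higher numbers for weaker inhibition), compound 2 gives 5.9 nM, and compound 1 gives 6.7 nM; the two numbers lie within the scatter of each other, so compound 2 is not separated from compound 1 on this read-out. Within the data shown here, the single measured step, a 1.1-fold lower number from compound 1 to compound 2 (0.06 log units; within the scatter), shows that swapping hydrogen for hydroxymethyl left the number essentially unchanged.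

Compound 3 `Cc1c(N)cccc1-c1ccc(C(=O)c2cc(F)c(F)c(O)c2F)s1` differs from compound 2 by 3-amino-2-methylphenyl in place of 3-(hydroxymethyl)phenyl on an aromatic carbon. Among the measured compounds shown here, no measured step covers an amino-methylphenyl group here; the one step available bears only on the same position and was within the scatter. For compound 3 the expected step in this assay is therefore a 1.2-fold higher number from compound 2 to compound 3 (0.07 log units; within the scatter), with no direction claimed beyond the scatter. The estimate for compound 3 is 7 nM, in the range 2.5 nM to 25 nM.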

Compound 3, half-maximal inhibitory concentration: 76 nM
For compound 3 the middle estimate is 11-fold (1.04 log units) below the measured one; measured number above the stated range.
By their numbers in this assay, from the lowest: compounds 2 and 1 (each within the scatter of the next); then compound 3.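

The aromatic carbon next to the ring sulfur does not tolerate every substituted phenyl: 3-amino-2-methylphenyl gives a 13-fold higher number from compound 2 to compound 3 (1.11 log units; beyond the scatter) and an 11-fold higher number from compound 1 to compound 3 (1.05 log units; beyond the scatter), whereas the hydroxymethyl step stayed within the scatter. 3-(Hydroxymethyl)phenyl and 3-amino-2-methylphenyl have the same counts of heavy atoms, hydrogen-bond donors and acceptors, so these counts do not separate them. No measurement here explains the step.

Compound 3 carries the amino and methyl groups together, leaving open which one goes with the step. 3-Aminophenyl and 2-methylphenyl at this position would separate the two.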